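The source may report more compounds than this note shows. Statements on the series, on what has been measured and on what is new or still open speak of the compounds shown alone.

Measured compounds:
- compound 1, `Cc1ccc(-c2nn(-c3ccccc3)cc2-c2nc3ccccc3n2S(=O)(=O)c2ccc(F)cc2)cc1`: 3670 nM
- compound 2, `Cc1ccc(-c2nn(-c3ccccc3)cc2-c2nc3ccccc3n2S(=O)(=O)c2ccc(Cl)cc2)cc1`: 4060 nM
- compound 3, `O=S(=O)(c1ccc(F)cc1)n1c(-c2cn(-c3ccccc3)nc2-c2ccc(F)cc2)nc2ccccc21`: 2440 nM

All three values come from a functional assay on HeLa cells (Homo sapiens) for antiproliferative activity, read by MTT assay, with a stated time of 24 h; on this read-out lower numbers stand for stronger inhibition and higher numbers for weaker inhibition. Compound 1 and compound 2 differ by chloro in place of fluoro on an aromatic carbon on the (4-fluorophenyl)sulfonyl part, and this step, a 1.1-fold higher number from compound 1 to compound 2 (0.04 log units; within the scatter), leaves the read-out essentially unchanged. The cores of compound 1 and compound 3 differ by fluoro in place of methyl on an aromatic carbon, a change on the other aryl ring; the step of a 1.5-fold lower number from compound 1 to compound 3 (0.18 log units; within the scatter) is also within the scatter, so no order among the three measured compounds can be stated.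

Compound 4, `O=S(=O)(c1ccc(Cl)cc1)n1c(-c2cn(-c3ccccc3)nc2-c2ccc(F)cc2)nc2ccccc21`, has not yet been measured in this assay. It differs from compound 3 by chloro in place of fluoro on an aromatic carbon, and its place line reads the same as for the change from compound 1 to compound 2, so this is the same change made on the core of compound 3. Among the measured compounds shown here, since the one earlier instance, a 1.1-fold higher number from compound 1 to compound 2 (0.04 log units; within the scatter), sat within the scatter, the corresponding step from compound 3 to compound 4 is expected to be of similar size, about a 1.1-fold higher number from compound 3 to compound 4 (0.04 log units; within the scatter), because the value of compound 3 in this assay is 2440 nM and the change itself gave no shift before. The estimate for compound 4 in this assay is therefore 2700 nM, expected to fall between 1500 nM and 5000 nM.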

Compound 4, half-maximal inhibitory concentration: 3450 nM
For compound 4 the middle estimate is 1.3-fold (0.11 log units) below the measured one, within the range that was stated.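

In this assay, chloro in place of fluoro on the (4-fluorophenyl)sulfonyl part gives a 1.4-fold higher number from compound 3 to compound 4 (0.15 log units; within the scatter), and this step agrees with its earlier instance on the other core: the same change on two cores in this assay, a 1.1-fold higher number (0.04 log units; within the scatter) from compound 1 to compound 2 and a 1.4-fold higher number (0.15 log units; within the scatter) from compound 3 to compound 4, 1.3-fold (0.11 log units) apart, within the scatter of two such steps

Fluoro in place of methyl on the other aryl ring, now read with chloro on the sulfonyl aryl ring, gives a 1.2-fold lower number from compound 2 to compound 4 (0.07 log units; within the scatter), and the two instances of this change agree in the same way: the same change on two cores in this assay, a 1.5-fold lower number (0.18 log units; within the scatter) from compound 1 to compound 3 and a 1.2-fold lower number (0.07 log units; within the scatter) from compound 2 to compound 4, 1.3-fold (0.11 log units) apart, within the scatter of two such steps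

This shows that each change gives steps within the scatter on both cores, so neither carries a detectable shift from one core to the other; it does not show that either change has no effect at all, since small real shifts would be hidden in the scatter, and two cores per change support no rule for the wider series.

The compounds shown vary only fluoro, chloro and methyl on two aryl rings, so it stays open whether an amine, a carboxylic acid or a methoxy group on an aromatic carbon would move the read-out beyond the scatter. On these data alone, the unsubstituted phenyl group on the shared core also stays open, as does whether any larger step would carry from one core to another.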